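Moving chlorine on the benzyl group of compound 2

A few compounds are considered here, and "the series" means these few. Any claim that something is new, unique, unknown or untested is made for them only; others in the source may bear on it.

Measured so far:
compound 1, `S=C(SCc1cn(Cc2ccccc2Cl)nn1)N1CCNCC1`: 38900 nM
compound 2, `CC(C)(C)OC(=O)N1CCN(C(=S)SCc2cn(Cc3ccc(Cl)cc3)nn2)CC1`: 2960 nM

Of the compounds shown here, two have been tested in a functional assay on MCF7 cells (Homo sapiens) for inhibition, read by MTT assay, with a stated time of 72 h; a lower number here means a stronger inhibitor, a higher number a weaker inhibitor. Compound 1 gives 38900 nM in this assay, and compound 2 gives 2960 nM. Compound 2 therefore holds the lowest number of the two, and the gap to compound 1 lies well beyond the scatter. Going by the values given here, compound 1 and compound 2 differ in more than one place, so no single step between them can be read from these two values.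

The next compound, compound 3, `CC(C)(C)OC(=O)N1CCN(C(=S)SCc2cn(Cc3ccccc3Cl)nn2)CC1`, keeps the core of compound 2 and changes only the benzyl group: 2-chlorophenyl in place of 4-chlorophenyl on a saturated chain carbon bound to an aromatic nitrogen. Among the compounds with values here, no step of this kind has yet been measured.

Compound 3 is expected to land somewhat weaker than compound 2, with a step of a 2.0-fold higher number from compound 2 to compound 3 (0.31 log units; beyond the scatter) that may still sit within the scatter; the lean toward a weaker number is partly because compound 1, which also carries 2-chlorophenyl, gives 38900 nM in this assay, though it differs from compound 3 elsewhere too. For compound 3 the estimated value is 6000 nM, expected to fall between 2000 nM and 20000 nM.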

Compound 3, half-maximal inhibitory concentration: 6090 nM
The estimate for compound 3 lay 1.0-fold (0.01 log units) below the measured number; measured number inside the range.
By their numbers in this assay, from the lowest: compound 2; then compound 3; then compound 1.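

In this assay, going by these compounds alone, the change from 4-chlorobenzyl to 2-chlorobenzyl gives a 2.1-fold higher number from compound 2 to compound 3 (0.31 log units; beyond the scatter), the first reading of a change at this place alone. It shows that with the same atoms, joined differently, the placement of chlorine on the benzyl group alters the number by a modest step that lies just beyond the scatter. Compound 3 also gives the first single-place reading at the ring amine nitrogen, where tert-butoxycarbonyl in place of hydrogen gives a 6.4-fold lower number from compound 1 to compound 3 (0.81 log units; beyond the scatter), a modest step that is the larger of the two new steps as printed, while the data shown include no measurement that bears on the reason for either step.

The compounds shown leave open how an unsubstituted benzyl group or a bromobenzyl group would read at the benzyl position, and whether the chlorine move would give a similar step with hydrogen on the ring amine nitrogen. They also leave open whether an acetyl group or a methyl group on that nitrogen would read like tert-butoxycarbonyl or like hydrogen.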